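Oral exposure notes: aryl ether to anilino swap

This account rests on a few compounds, and the source may have more. Where it says the series, first, only, none or still open, it means among the compounds named here.

compound 1 `Cc1cc(-c2cnn3c(NCC4CCOCC4)nc(Oc4cccc(F)c4F)nc23)ccc1C(=O)NC1CC1` — 2990 nM
compound 2 `Cc1cc(-c2cnn3c(NCC4CCOCC4)nc(Nc4cccc(F)c4)nc23)ccc1C(=O)NC1CC1` — "not determined" (no result reported)

In an ADME assay on the whole organism for pharmacokinetics, with Mus musculus as the target, at a dose of 10 mg/kg by the oral route (on this read-out lower numbers stand for lower exposure and higher numbers for higher exposure at the dose given), compound 1 gives 2990 nM. For the measured compounds named here, this is the only number in hand for the series: compound 2 `Cc1cc(-c2cnn3c(NCC4CCOCC4)nc(Nc4cccc(F)c4)nc23)ccc1C(=O)NC1CC1` carries "not determined" (no result reported), so nothing can be said about how it compares with compound 1, and compound 1 stands alone as the single reference point. Compound 3 `Cc1cc(-c2cnn3c(NCC4CCOCC4)nc(Nc4ccccc4F)nc23)ccc1C(=O)NC1CC1` differs from compound 1 in one place, ((2-fluorophenyl)amino in place of 2,3-difluorophenoxy on an aromatic carbon). Going by the values given here, no step from one measured compound to another is available, so there is no measured guide to the size of this change. With a single reference value, the step from compound 1 to compound 3 is expected to be a 1.2-fold lower number from compound 1 to compound 3 (0.08 log units; within the scatter), that is, no step beyond the usual scatter in either direction. Compound 3 is therefore estimated at 2500 nM in this assay, with a range from 700 nM to 9000 nM.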

Compound 3, maximal plasma concentration: 1180 nM
Compound 3: middle estimate off by 2.1-fold (0.33 log units), on the high side; the range from low to high includes it.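

In this assay, replacing 2,3-difluorophenoxy with (2-fluorophenyl)amino on the aromatic carbon between two ring nitrogen atoms gives a 2.5-fold lower number from compound 1 to compound 3 (0.40 log units; beyond the scatter). For the compounds shown here, this is the first measured sign that the group at this position can shift oral exposure beyond the usual scatter, although the step is modest in size. The change alters the linking atom and the fluorine count together, and (2-fluorophenyl)amino has 1 hydrogen-bond donor where 2,3-difluorophenoxy has 0, so this single step cannot assign the shift to any one of these differences, and no measurement explaining it is in hand.

Still open, as far as these compounds go, is whether 2-fluorophenoxy or (2,3-difluorophenyl)amino at this position would separate the contribution of the linking atom from that of the second fluorine. The compounds shown also leave open how a non-aromatic amine such as morpholine would read here.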